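Swapping methyl for trifluoromethyl on the amide-side ring

The compounds below may be only part of what the source reports. "The series", "measured", "known", "first", "only" and "open" are said of these compounds alone.

Of the compounds shown here, three built on one shared core have been measured in a functional assay on CHO-K1 cells for antagonist activity at muscarinic acetylcholine receptor M5 (Homo sapiens), read by calcium flux; on this read-out higher numbers stand for weaker inhibition and lower numbers for stronger inhibition. Compound 1 `CCN1CCN(c2ccc(NC(=O)c3ccccc3OC)cc2Cl)CC1` gives 1300 nM. Compound 2 `CCN1CCN(c2ccc(NC(=O)c3cccc(C)c3)cc2Cl)CC1` gives 3500 nM, which is the higher of the two plain numbers. Compound 3 `CCN1CCN(c2ccc(NC(=O)c3ccc(OC)cc3)cc2Cl)CC1` reaches only the limit of the assay, > 10000 nM, so no number is known for it (the limit of > 10000 nM in this assay, at which 1 of the 3 values shown sits). The step of a 2.7-fold higher number from compound 1 to compound 2 (0.43 log units; beyond the scatter) is modest, and the step of an at least 2.8-fold higher number from compound 2 to compound 3 (0.45 log units; beyond the scatter) is modest or more. Both of these steps move a small group around the ring attached to the carbonyl rather than change what that group is.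

Compound 4 `CCN1CCN(c2ccc(NC(=O)c3cccc(C(F)(F)F)c3)cc2Cl)CC1` is compound 2 with a different group at the same place: trifluoromethyl in place of methyl on an aromatic carbon. Among the compounds with values here, no measured step exchanges one small group for another at a fixed position, so the measured steps give little guide here. The expectation for compound 4 is therefore a step of no change at the digits printed from compound 2 to compound 4 (within the scatter), that is, no change beyond the scatter. Compound 4 is accordingly estimated at 3500 nM, within a range from 1200 nM to 10000 nM.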

Compound 4, half-maximal inhibitory concentration: 4100 nM
Beside the measured number, compound 4's estimate is 1.2-fold (0.07 log units) below it; the measured number falls inside the stated range.
By their numbers in this assay, from the lowest: compound 1; then compounds 2 and 4 (each within the scatter of the next). At a limit, above all of these: compound 3.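

At this place on the ring attached to the carbonyl, in this assay, trifluoromethyl in place of methyl gives a 1.2-fold higher number from compound 2 to compound 4 (0.07 log units; within the scatter). Within the data shown here, this is the first measured exchange of one small group for another at a fixed position: a group with more heavy atoms, fluorine among them, makes no change beyond the scatter, whereas the earlier steps, which all changed where on the ring a group sits, lay beyond it. Nothing in the data shown bears on the reason for this result.

On these data alone, it remains open whether the same exchange would leave the number unchanged at the other ring positions seen in compound 1 and compound 3. As far as these compounds go, it is also open how an amine, a carboxylic acid or a longer chain such as butyl would fare at the place held by methyl in compound 2.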